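Lengthening a methyl to butyl on the shared core

A few compounds are considered here, and "the series" means these few. Any claim that something is new, unique, unknown or untested is made for them only; others in the source may bear on it.

Measured in a functional assay on MDA-MB-231 cells (Homo sapiens) for antiproliferative activity, with a stated time of 4 days; a higher number here means a weaker inhibitor, a lower number a stronger inhibitor:
- compound 1 `COc1ccc(-c2[nH]c3ccc(F)cc3c2C=C(C#N)C#N)cc1`: 400 nM
- compound 2 `COc1ccc(-c2[nH]c3ccc(C)cc3c2C=C(C#N)C#N)cc1`: 280 nM
- compound 3 `COc1ccc(-c2[nH]c3cc(Cl)c(C)cc3c2C=C(C#N)C#N)cc1`: 75 nM

Compound 2 lies within the scatter of compound 1, while compound 3 sits clearly lower, as a 3.7-fold lower number from compound 2 to compound 3 (0.57 log units; beyond the scatter) shows. The next compound is compound 4 `CCCCc1ccc2[nH]c(-c3ccc(OC)cc3)c(C=C(C#N)C#N)c2c1`, where the methyl of compound 2 grows to butyl: propyl in place of hydrogen on a saturated chain carbon bound to an aromatic carbon.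

The closest guide is a 1.4-fold lower number from compound 1 to compound 2 (0.15 log units; within the scatter), methyl in place of fluoro. The chloro step bears less, since it is a different change. Among the measured compounds shown here, no measured compound carries a longer chain, so the direction stays open. The expected result is a 1.1-fold higher number from compound 2 to compound 4 (0.03 log units; within the scatter), with no clear shift in this assay. For compound 4 the estimated value is 300 nM, with an expected range of 100 nM to 900 nM.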

Compound 4, half-maximal inhibitory concentration: 26 nM
Compound 4: the middle estimate sits 12-fold (1.06 log units) above what was measured; the whole stated range lies above it.
By their numbers in this assay, from the lowest: compound 4; then compound 3; then compounds 2 and 1 (each within the scatter of the next).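

In this assay the growth of methyl to butyl is a large step (an 11-fold lower number from compound 2 to compound 4 (1.03 log units; beyond the scatter)), while the swap of fluoro for methyl at the same place stayed within the scatter (a 1.4-fold lower number from compound 1 to compound 2 (0.15 log units; within the scatter)), so this place is far more sensitive to chain length than the smaller groups suggested. Butyl in place of fluoro is also a large step (a 15-fold lower number from compound 1 to compound 4 (1.19 log units; beyond the scatter)). Nothing measured here explains the gain.

Chains such as ethyl, propyl or hexyl at this place remain open, so the best length is unknown. Also open, on these data alone, is how an amine at the end of the chain would behave.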